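Swapping a Hydroxylated Branch for a Methoxymethyl Side Chain

The source may report more compounds than this note shows. Statements on the series, on what has been measured and on what is new or still open speak of the compounds shown alone.

Of the compounds shown here, three have so far been measured in an assay (Equus caballus) for inhibition of Thromboxane-A synthase (Homo sapiens), using microsomes; a lower number here means a stronger inhibitor, a higher number a weaker inhibitor. Compound 1 `CC(C)(O)C(CCC/C=C(\c1ccccc1)c1cccnc1)C(=O)O` gives 42 nM, the highest of the three numbers. Compound 3 `O=C(O)C(CCC/C=C(/c1cccnc1)c1cccs1)c1ccccc1` gives 32 nM, a value that lies within the usual scatter of compound 1's, so the two cannot be told apart. Compound 2 `O=C(O)CCCC/C=C(\c1cccnc1)c1cccs1` gives 20 nM, which lies beyond that scatter and below compound 1. Compound 4 `COCC(CCC/C=C(\c1ccccc1)c1cccnc1)C(=O)O` has not yet been measured; it differs from compound 1 in one place: methoxymethyl in place of 1-hydroxy-1-methylethyl on a saturated chain carbon bound to a carbonyl carbon and a saturated chain carbon. For the measured compounds named here, no two measured compounds differ in a single place, so there is no measured step to lean on. The step from compound 1 to compound 4 is expected to be small, a 1.4-fold higher number from compound 1 to compound 4 (0.15 log units; within the scatter), with no direction clearly beyond the scatter. Compound 4 is therefore estimated at 60 nM, within a range from 25 nM to 150 nM.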

Compound 4, half-maximal inhibitory concentration: 41 nM
Estimate against measurement, compound 4: 1.5-fold (0.17 log units) above; the range from low to high includes it.
By their numbers in this assay, from the lowest: compounds 2, 3, 4 and 1 (each within the scatter of the next, the first and the last beyond it).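

For the compounds shown here, the first single-place step reads a 1.0-fold lower number from compound 1 to compound 4 (0.01 log units; within the scatter) in this assay, so on this saturated chain carbon, methoxymethyl and 1-hydroxy-1-methylethyl cannot be told apart. Methoxymethyl carries 0 hydrogen-bond donors where 1-hydroxy-1-methylethyl carries 1, yet the two numbers stay within the scatter. Nothing measured here explains this match. Still open, on these data alone, is whether a hydroxymethyl group, which would restore the donor on a shorter branch, would also match. An amine or a longer chain at this carbon remains equally untested.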